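Trading an indolyl group for a methylindolyl group

This account rests on a few compounds, and the source may have more. Where it says the series, first, only, none or still open, it means among the compounds named here.

Compound 1 `COc1ccc(-c2cc3nccc(-c4cc(OC)c(OC)c(OC)c4)n3n2)cc1N`: 251 nM
Compound 2 `COc1ccc(-c2cc3nccc(-c4cc(OC)c(OC)c(OC)c4)n3n2)cc1F`: 2840 nM
Compound 3 `COc1cc(-c2ccnc3cc(-c4c[nH]c5ccccc45)nn23)cc(OC)c1OC`: 35 nM

In a functional assay on HCT-116 cells (Homo sapiens) for inhibition, read by CCK-8 assay, with a stated time of 48 h (a lower number here means a stronger inhibitor, a higher number a weaker inhibitor), compound 3 gives the lowest number of the three, and its steps to both other compounds lie beyond the scatter. Compound 4 `COc1cc(-c2ccnc3cc(-c4ccc5ccn(C)c5c4)nn23)cc(OC)c1OC` differs from it in one place: 1-methyl-1H-indol-6-yl in place of 1H-indol-3-yl on an aromatic carbon. Among the measured compounds shown here, two measured steps bear on that position. Exchanging the aryl group there moved the number by a 7.2-fold lower number from compound 1 to compound 3 (0.86 log units; beyond the scatter) and by an 81-fold lower number from compound 2 to compound 3 (1.91 log units; beyond the scatter), and removing an amino group at a nearby site gave an 11-fold higher number from compound 1 to compound 2 (1.05 log units; beyond the scatter). The position is therefore sensitive, and the change from compound 3 to compound 4 is expected to raise the number in this assay by about a 5.7-fold higher number from compound 3 to compound 4 (0.76 log units; beyond the scatter). Compound 4 is thus estimated at 200 nM, with a likely range from 50 nM to 900 nM.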

Compound 4, half-maximal inhibitory concentration: 1040 nM
Beside the measured number, compound 4's estimate is 5.2-fold (0.72 log units) below it; measured number above the stated range.
By their numbers in this assay, from the lowest: compound 3; then compound 1; then compound 4; then compound 2.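

In this assay, an indole at this position does not by itself secure the low number of compound 3 (a 30-fold higher number from compound 3 to compound 4 (1.47 log units; beyond the scatter)). The 1-methyl-1H-indol-6-yl group gives up the advantage over the 3-amino-4-methoxyphenyl group (a 4.1-fold higher number from compound 1 to compound 4 (0.62 log units; beyond the scatter)), yet it still improves on the 3-fluoro-4-methoxyphenyl group (a 2.7-fold lower number from compound 2 to compound 4 (0.44 log units; beyond the scatter)). The identity of the indole group therefore matters as much here as the choice between an indole and a phenyl group.

The compounds shown leave open how much of the loss follows the methyl on the ring nitrogen and how much the attachment point, which a 1-methyl-1H-indol-3-yl group would help separate. No evidence on hand accounts for the loss.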